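This account rests on a few compounds, and the source may have more. Where it says the series, first, only, none or still open, it means among the compounds named here.

Measured so far:
compound 1 `Cc1cc(-c2ccc(F)cc2)nnc1N1CCN(c2ncccn2)CC1` — in a functional assay on BV-2 cells (Mus musculus) for inhibition, read by ELISA, with a stated time of 16 h (on this read-out higher numbers stand for weaker inhibition and lower numbers for stronger inhibition), compound 1 gives 76300 nM
compound 2 `Cc1ccc(-c2cc(C)c(N3CCN(c4ncccn4)CC3)nn2)cc1` — in this assay compound 2 gives 17200 nM

Among the compounds with values here, compound 2 holds the lowest number of the two; its only neighbour is compound 1, and the step of a 4.4-fold lower number from compound 1 to compound 2 (0.65 log units; beyond the scatter) is beyond the scatter. Within the data shown here, that step is the sole measured change in the set.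

Compound 3 `Cc1cc(-c2cncnc2)nnc1N1CCN(c2ncccn2)CC1` is not yet measured. It differs from compound 2 by pyrimidin-5-yl in place of 4-methylphenyl on an aromatic carbon. Among the measured compounds shown here, no measured step covers this exchange directly. For the measured compounds named here, the one measured step, a 4.4-fold lower number from compound 1 to compound 2 (0.65 log units; beyond the scatter), concerns a change at a different position, the group on the six-membered aromatic ring of carbon only, and shows that altering that ring shifts the number by a modest amount. Here the whole 4-methylphenyl is replaced, so the methyl whose presence accompanied the lower number of compound 2 is gone; a move back toward higher numbers is expected, a 3.5-fold higher number from compound 2 to compound 3 (0.54 log units; beyond the scatter). For compound 3 the estimate in this assay is 60000 nM, within 20000 nM to 200000 nM.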

Compound 3, half-maximal inhibitory concentration: > 100000 nM
Compound 3: only a limit was reported (the forecaster's own chance of this, stated with the estimate: 30%); at least 1.6-fold (0.22 log units) between middle value and limit.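

In this assay compound 3 carries a limit and not a number: the limit of > 100000 nM in this assay, at which 1 of the 3 values shown sits. Exchanging the whole 4-methylphenyl for pyrimidin-5-yl, with its two ring nitrogens, gives an at least 5.8-fold higher number from compound 2 to compound 3 (0.76 log units; beyond the scatter), so this position responds to replacing the ring itself and not only to changing the group on it. Against 4-fluorophenyl the same exchange gives an at least 1.3-fold higher number from compound 1 to compound 3 (0.11 log units; that floor lies within the scatter), and with that floor no order between these two can be read.

Open, going by these compounds, is whether a plain phenyl or a pyridin-3-yl at this position would separate the two parts of the exchange, the ring nitrogens and the lost methyl. Also open, on these data alone, is how a phenyl ring carrying an amine or a carboxylic acid would read here.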